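The compounds below may be only part of what the source reports. "The series", "measured", "known", "first", "only" and "open" are said of these compounds alone.

Measured in a functional assay on MCF7 cells (Homo sapiens) for cytotoxicity, read by fluorescence, with a stated time of 72 h; on this read-out higher numbers stand for weaker inhibition and lower numbers for stronger inhibition
Compound 1 `CC(C)c1n[nH]c2c(NCc3ccc(-c4ccccn4)cc3)nc(NCCN)nc12` gives 62 nM
Compound 2 `CC(C)c1n[nH]c2c(NCc3ccc(-c4ccccn4)cc3)nc(NCCN(C)C)nc12` gives 225 nM
Compound 3 `COc1ccc(CNc2nc(NCc3ccc(-c4ccccn4)cc3)c3[nH]nc(C(C)C)c3n2)cc1` gives 5300 nM

Compound 3 has the highest number of the three and is the weakest. Compound 4 `CC(C)c1n[nH]c2c(NCc3ccc(-c4ccccn4)cc3)nc(NCc3ccc(-c4ccccn4)cc3)nc12` differs from it in one place: pyridin-2-yl in place of methoxy on an aromatic carbon. In short, pyridin-2-yl stands in place of methoxy on an aromatic carbon. For the measured compounds named here, no measured step makes this change. The closest evidence is two large steps: an 85-fold higher number from compound 1 to compound 3 (1.93 log units; beyond the scatter) and a 24-fold higher number from compound 2 to compound 3 (1.37 log units; beyond the scatter). Each replaces an amine-bearing group with 4-methoxyphenyl. Compound 4 has no such amine-bearing group either, so no step beyond the scatter is expected in this assay, though the data favour neither direction. The expected step is a 1.1-fold lower number from compound 3 to compound 4 (0.03 log units; within the scatter). Compound 4 is estimated at 5000 nM, within a range of 1500 nM to 17000 nM.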

Compound 4, half-maximal inhibitory concentration: 2390 nM
For compound 4 the middle estimate is 2.1-fold (0.32 log units) above the measured one; the range from low to high includes it.
By their numbers in this assay, from the lowest: compound 1; then compound 2; then compound 4; then compound 3.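

In this assay, pyridin-2-yl in place of methoxy on this aromatic carbon gives a 2.2-fold lower number from compound 3 to compound 4 (0.35 log units; beyond the scatter), so a change at the far end of this side group can still shift the number, though only modestly. That gain recovers little of the gap to the amine-bearing chains, which remains large, with an 11-fold higher number from compound 2 to compound 4 (1.03 log units; beyond the scatter) and a 39-fold higher number from compound 1 to compound 4 (1.59 log units; beyond the scatter). No accompanying measurement gives a reason for either effect.

Still open, going by these compounds, is whether an amine or a carboxylic acid on this aromatic carbon would lower the number further. On these data alone, whether a longer aminoalkyl chain would improve on the short amine-bearing chains also remains unknown.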